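This account rests on a few compounds, and the source may have more. Where it says the series, first, only, none or still open, it means among the compounds named here.

Of the compounds shown here, three have been measured in a functional assay on CHO cells for agonist activity at Free fatty acid receptor 1 (Homo sapiens), read by a luciferase reporter; a higher number here means a larger maximal response, a lower number a smaller maximal response. Compound 1, `O=C(O)COc1ccc(NCc2cccc(Oc3ccccc3)c2)cc1`, gives 84%. Compound 2, `Cc1nc(-c2ccc(C(F)(F)F)cc2)sc1CNc1ccc(OCC(=O)O)cc1`, gives 100%, the highest of the three, with compound 1 nearest and compound 3 furthest. Compound 3, `CC(Cc1ccc(NCc2cccc(Oc3ccccc3)c2)cc1)C(=O)O`, gives 70%.

Compound 3 is compound 1 with one change, (2-carboxypropyl in place of carboxymethoxy on an aromatic carbon). This change made the maximal response a number 14 percentage points lower from compound 1 to compound 3 (beyond the scatter), a modest drop that lies beyond the scatter. Compound 1 and compound 2 differ by a large part of the molecule, and the difference between the two cores is not broken down here.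

Compound 4, `Cc1nc(-c2ccc(C(F)(F)F)cc2)sc1CNc1ccc(CC(C)C(=O)O)cc1`, is not yet measured. It is compound 2 with 2-carboxypropyl in place of carboxymethoxy on an aromatic carbon. The surroundings of the changed place are described in the same words for both pairs, so this is the same change already seen from compound 1 to compound 3. Its step is expected to be similar, a number 14 percentage points lower from compound 2 to compound 4 (beyond the scatter), resting on the drop a number 14 percentage points lower from compound 1 to compound 3 (beyond the scatter). Compound 4 is therefore expected to give about 86%, estimated between 70% and 100%.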

Compound 4, largest response reached (reported as percent of maximum), in percent of the reference or control that the assay uses: 100%
Beside the measured number, compound 4's estimate is 14 percentage points below it; measured number inside the range.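

In this assay, putting 2-carboxypropyl in place of carboxymethoxy on the core of compound 2 gave no change at the digits printed from compound 2 to compound 4 (within the scatter). Set beside the same change on the core of compound 1, the two steps cannot be told apart: the same change on two cores in this assay, a number 14 percentage points lower (beyond the scatter) from compound 1 to compound 3 and no change at the digits printed (within the scatter) from compound 2 to compound 4, 14 percentage points apart, within the scatter of two such steps. Within the data shown here, this means the data give no sign that the core alters what this change does, but they do not prove that its effect is the same on both cores, since one step lies beyond the scatter, the other lies within it, and only two pairs are available.

The compounds shown leave open whether the change would behave the same way on a third core, and they cover only the largest response reached, not how much compound is needed to reach it. They also leave open what a longer chain ending in the carboxylic acid, or an amide in place of that acid, would do on either core.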